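The compounds below may be only part of what the source reports. "The series", "measured", "known", "first", "only" and "open" are said of these compounds alone.

In an in vitro assay on cells for displacement of a labelled ligand from thyroid hormone receptor beta (Homo sapiens), with a stated time of 48 h (a lower number here means a stronger inhibitor, a higher number a weaker inhibitor), three compounds have been measured so far:

compound 1 `Cc1cc(NC(=O)CC(=O)O)c2c(c1Oc1ccc(O)c(CC(C)C)c1)CCC2` gives 39.9 nM
compound 2 `Cc1cc(NC(=O)CC(=O)O)c2c(c1Oc1ccc(O)c(CCc3ccc(F)cc3)c1)CCC2` gives 8.2 nM
compound 3 `Cc1cc(NC(=O)CC(=O)O)c2c(c1Oc1ccc(O)c(CCc3ccc(F)c(F)c3)c1)CCC2` gives 6 nM

Compound 3 has the lowest of the three numbers. Its nearest neighbour is compound 2, whose value lies within the scatter of it; its furthest is compound 1, which lies beyond the scatter.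

Compound 4 `Cc1cc(NC(=O)CC(=O)O)c2c(c1Oc1ccc(O)c(CCc3cccc(O)c3)c1)CCC2` is the next step from compound 3. The change is 3-hydroxyphenyl in place of 3,4-difluorophenyl on a saturated chain carbon, two bonds along the chain from an aromatic carbon.

Going by the values given here, two measured steps touch this position. The step of a 4.9-fold lower number from compound 1 to compound 2 (0.69 log units; beyond the scatter) and the step of a 6.7-fold lower number from compound 1 to compound 3 (0.82 log units; beyond the scatter) show that a substituted benzyl in place of isopropyl at this chain carbon gives a modestly lower number. The step of a 1.4-fold lower number from compound 2 to compound 3 (0.14 log units; within the scatter) shows that one more fluoro on that ring changes nothing beyond the scatter. Among the compounds with values here, no measured compound carries a hydroxyl on this ring, so the effect of trading both fluorines for a hydroxyl is not covered by the data. Since the ring substituents have so far moved this assay little, a step near the scatter is expected for compound 4, a 1.7-fold higher number from compound 3 to compound 4 (0.22 log units; within the scatter), with a wider range to reflect the new group. Compound 4 is therefore estimated at 10 nM, between 4 nM and 30 nM.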

Compound 4, inhibition constant: 81.3 nM
The estimate for compound 4 lay 8.1-fold (0.91 log units) below the measured number; measured number above the stated range.
By their numbers in this assay, from the lowest: compounds 3 and 2 (each within the scatter of the next); then compound 1; then compound 4.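

In this assay, the groups on this ring prove to matter far more than the two fluorinated compounds suggested: 3-hydroxyphenyl in place of 3,4-difluorophenyl gives a 14-fold higher number from compound 3 to compound 4 (1.13 log units; beyond the scatter) and in place of 4-fluorophenyl gives a 9.9-fold higher number from compound 2 to compound 4 (1.00 log units; beyond the scatter) even though the fluoro step between those two rings stayed within the scatter. The lower numbers seen on replacing isopropyl therefore do not hold for every substituted benzyl, since 3-hydroxybenzyl in place of isopropyl gives a 2.0-fold higher number from compound 1 to compound 4 (0.31 log units; beyond the scatter) and so moves the number the opposite way from 4-fluorobenzyl and 3,4-difluorobenzyl. Nothing available explains why the hydroxyl-bearing ring differs from the fluorinated rings.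

The compounds shown leave open whether the higher number comes from the hydroxyl itself or from the loss of the fluorines, a question that a plain phenyl ring would help to separate. They also leave open how a methoxy group or an amine in place of the hydroxyl on this ring would read in this assay and whether a hydroxyl alongside a fluoro would keep any of the lower numbers.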